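Trifluoromethyl in Place of Cyano, Tried a Second Time

The source may hold more compounds than are shown below. What is called first, only, known or untested is meant among the compounds shown, and "the series" means these compounds.

The measured compounds are:
compound 1, `CC1(C)Oc2ccc(C#N)cc2[C@@H](N2CCCCC2=O)[C@@H]1O`, giving 270 nM
compound 2, `CC1(C)Oc2ccc(C(F)(F)F)cc2[C@@H](N2CCCCC2=O)[C@@H]1O`, giving 58 nM
compound 3, `CC1(C)C=C(N2CCCCC2=O)c2cc(C#N)ccc2O1`, giving 1100 nM

In a functional assay (trachea) for inhibition, with Cavia porcellus as the target (a lower number here means a stronger inhibitor, a higher number a weaker inhibitor), compound 1 gives 270 nM, while compound 2 gives 58 nM. The two share one core and differ by trifluoromethyl in place of cyano on an aromatic carbon; that change brought a 4.7-fold lower number from compound 1 to compound 2 (0.67 log units; beyond the scatter). Compound 3 gives 1100 nM in this assay, the highest of the three numbers, and it carries the cyano group on a different core. How the core of compound 3 differs from the core of compound 1 is not broken down here.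

Compound 4, `CC1(C)C=C(N2CCCCC2=O)c2cc(C(F)(F)F)ccc2O1`, is not yet measured in this assay. It stands to compound 3 as compound 2 stands to compound 1: the difference is trifluoromethyl in place of cyano on an aromatic carbon, and the place of the change is described in the same words for both pairs, so this is the same change made on a second core. The expectation for compound 4 rests on the earlier step, because a 4.7-fold lower number from compound 1 to compound 2 (0.67 log units; beyond the scatter) was seen when the same change was made on the core of compound 1. Among the compounds with values here, since only one earlier example exists, the step for compound 4 is estimated to be of similar size but with room for it to be smaller, a 4.1-fold lower number from compound 3 to compound 4 (0.61 log units; beyond the scatter). Compound 4 is therefore expected to give 270 nM in this assay, with a likely range from 120 nM to 650 nM.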

Compound 4, half-maximal inhibitory concentration: 650 nM
Beside the measured number, compound 4's estimate is 2.4-fold (0.38 log units) below it; the range from low to high includes it.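

On the second core, trifluoromethyl in place of cyano gave in this assay a 1.7-fold lower number from compound 3 to compound 4 (0.23 log units; within the scatter), so on this core the two groups cannot be told apart by this read-out. The gain seen on the core of compound 1 therefore did not carry over at the same size, and the two steps differ by more than repeated measurement would explain: the same change on two cores in this assay, a 4.7-fold lower number (0.67 log units; beyond the scatter) from compound 1 to compound 2 and a 1.7-fold lower number (0.23 log units; within the scatter) from compound 3 to compound 4, 2.8-fold (0.44 log units) apart, beyond the scatter of two such steps. This shows that, for these two pairs, the size of the step depends on the core it is made on, but it does not show which feature of the core matters, and with one pair per core it gives no general rule for the series.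

Whether the larger or the smaller step is the more usual one stays open, since only two cores are shown, and so does how other groups on that aromatic carbon, such as a chlorine atom, a methyl group, an amine or a carboxylic acid, would read in this assay on either core. Also open, from the compounds shown here alone, is whether the difference between the two steps would persist with an open-chain amide in place of the ring that carries the carbonyl.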